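Trimming the ester chain of compound 3 to ethyl

This account rests on a few compounds, and the source may have more. Where it says the series, first, only, none or still open, it means among the compounds named here.

Among the compounds with values here, compound 3 `CCCCOC(=O)C(O)Cn1cnc2c(N)ncnc21` is the only compound of this set that gives a number in a functional assay on HeLa cells (Homo sapiens) for cytotoxicity; a higher number here means that more compound is tolerated, a lower number that less compound is tolerated: compound 3 gives 400 ug/mL. Compound 1 `COCCOC(=O)C(O)Cn1cnc2c(N)ncnc21` reaches only a limit of the assay in this assay, > 400 ug/mL. Compound 2 `CC(C)COC(=O)C(O)Cn1cnc2c(N)ncnc21` likewise stops at a limit in this assay, > 400 ug/mL. The step from these two compounds to compound 3 is therefore a number no higher from compound 1 to compound 3 (the limit leaves the size open) and a number no higher from compound 2 to compound 3 (the limit leaves the size open), and the step between the two limits is a step that the two limits leave unreadable from compound 1 to compound 2; all this follows from the limit of > 400 ug/mL in this assay, at which 2 of the 3 values shown sit.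

Compound 4 `CCOC(=O)C(O)Cn1cnc2c(N)ncnc21` carries a shorter chain than compound 3, the change being (hydrogen in place of ethyl on a saturated chain carbon, two bonds along the chain from an oxygen next to a carbonyl group). Within the data shown here, no measured step of this kind exists; the nearest, the ethyl-for-methoxy exchange in a number no higher from compound 1 to compound 3 (the limit leaves the size open), gives no readable size. The step is therefore expected to stay within the usual scatter, no change at the digits printed from compound 3 to compound 4 (within the scatter), with a fair chance that only a limit is reported. Compound 4 is thus estimated at 400 ug/mL, between 200 ug/mL and 800 ug/mL.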

Compound 4, minimum cytotoxic concentration: > 400 ug/mL
Compound 4: a limit, no number; the forecaster's own chance of this, stated with the estimate: 50%; the middle value lies on the limit itself.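

In this assay compound 4 reaches only a limit, > 400 ug/mL. Hydrogen in place of ethyl on this saturated chain carbon, a plain shortening of the chain with no oxygen or branch involved, gives a number no lower from compound 3 to compound 4 (the limit leaves the size open), so at this position the shorter chain does not bring the number down. Within the data shown here, compound 3 remains the only compound here with a real number: the limit of > 400 ug/mL in this assay, at which 3 of the 4 values shown sit. The steps from compound 1 and compound 2 to compound 4 cannot be read, as both ends of each are limits.

From the compounds shown here alone, how far the true values of compound 1, compound 2 and compound 4 lie past the limit stays unknown, so these ester chains cannot be ranked. Going by these compounds, whether a hexyl chain on the ester, or a carboxylic acid in its place, would give a lower number than compound 3 also stays open.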